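Shifting the oxolane attachment point on a shared core

A few compounds are considered here, and "the series" means these few. Any claim that something is new, unique, unknown or untested is made for them only; others in the source may bear on it.

In an assay on HEK293 cells for displacement of a labelled ligand from corticotropin-releasing factor receptor 1 (Homo sapiens), read by scintillation counting, with a stated time of 2 h (on this read-out higher numbers stand for weaker inhibition and lower numbers for stronger inhibition), compound 1 `COCc1cc(OC)c(-c2cccc3c(N(CC4CCOCC4)CC4CC4)c(C#N)nn23)c(OC)c1` gives 52 nM. Compound 2 `CCc1nn2c(-c3c(C)cc(C)cc3OC)cccc2c1N(CC1CC1)CC1CCCO1` gives 34 nM in this assay. Compound 2 holds the lower of the two numbers, yet its gap to compound 1 lies within the scatter, so the two cannot be separated on this evidence. Compound 3 `CCc1nn2c(-c3c(C)cc(C)cc3OC)cccc2c1N(CC1CC1)CC1CCOC1` is the unmeasured partner of compound 2 and differs from it by oxolan-3-yl in place of oxolan-2-yl on a saturated chain carbon bound to a nitrogen on an aromatic ring, the same atoms joined differently. Going by the values given here, no measured pair shows a change of this kind, so its effect has no precedent here. The expected step is a 1.3-fold higher number from compound 2 to compound 3 (0.12 log units; within the scatter), which is no more than the scatter, in no firm direction. Compound 3 is therefore estimated at 45 nM, with a range from 15 nM to 140 nM.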

Compound 3, half-maximal inhibitory concentration: 38 nM
Compound 3: middle estimate off by 1.2-fold (0.07 log units), on the high side; low and high end bracket the measured number.
By their numbers in this assay, from the lowest: compounds 2, 3 and 1 (each within the scatter of the next).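

In this assay, exchanging oxolan-2-yl for oxolan-3-yl on the saturated chain carbon bound to a nitrogen on an aromatic ring gives a 1.1-fold higher number from compound 2 to compound 3 (0.05 log units; within the scatter) and is the only one-place step among these compounds. At this position on the shared core, the two oxolane attachments therefore cannot be told apart on this read-out, so moving the attachment point has no effect that can be separated from the scatter. Nothing measured here offers an explanation for this reading.

From the compounds shown here alone, this single pair speaks only for these two oxolane groups on this core, so it remains open whether the same holds on the core of compound 1. Also open, going by these compounds, is how the position responds to different atoms, such as pyrrolidin-3-yl, an amine with a ring nitrogen in place of the oxolane oxygen, or a carboxylic acid.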